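The source may hold more compounds than are shown below. What is called first, only, known or untested is meant among the compounds shown, and "the series" means these compounds.

Compound 1 `CN(C)S(=O)(=O)c1ccccc1Nc1cc(-c2ccc3ccn(C)c3c2)c2nccnc2c1` and compound 2 `CN1CCCC(NS(=O)(=O)c2ccccc2Nc2cc(-c3ccc4ccn(C)c4c3)c3nccnc3c2)C1` share one core and differ only in the group carried on a sulfonyl sulfur. In an assay on lysate for inhibition of 6-phosphofructo-2-kinase/fructose-2,6-bisphosphatase 3 (Homo sapiens), with stated times of 0.5 min and 45 min (a higher number here means a weaker inhibitor, a lower number a stronger inhibitor), compound 1 gives 7670 nM, the smaller of the two numbers recorded, though its gap to compound 2 lies within the scatter, and compound 2 gives 9780 nM. The step of a 1.3-fold higher number from compound 1 to compound 2 (0.11 log units; within the scatter) shows that exchanging dimethylamino for (1-methylpiperidin-3-yl)amino left the number essentially where it was.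

Compound 3 `Cn1ccc2ccc(-c3cc(Nc4ccccc4S(=O)(=O)NCC4CCOCC4)cc4nccnc34)cc21` has not yet been measured. It differs from compound 1 in one place: ((oxan-4-yl)methyl)amino in place of dimethylamino on a sulfonyl sulfur. Going by the values given here, only one measured step bears on this kind of change, a 1.3-fold higher number from compound 1 to compound 2 (0.11 log units; within the scatter), in which a different amino group replaced the same dimethylamino at the same sulfonyl sulfur and the result stayed within the scatter. On that basis the change from compound 1 to compound 3 is expected to stay within the scatter as well, with no direction to call, so the estimated step is a 1.0-fold higher number from compound 1 to compound 3 (0.02 log units; within the scatter). The expected value for compound 3 in this assay is 8000 nM, with a range from 3500 nM to 18000 nM.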

Compound 3, half-maximal inhibitory concentration: > 100000 nM
Compound 3: a limit, no number (the forecaster's own chance of this, stated with the estimate: 5%); middle value at least 12-fold (1.09 log units) from the limit.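

For compound 3 the record is a limit of the assay and not a number: the limit of > 100000 nM in this assay, at which 1 of the 3 values shown sits. Even so, both new steps lie beyond the scatter, with an at least 13-fold higher number from compound 1 to compound 3 (1.11 log units; beyond the scatter), and with an at least 10-fold higher number from compound 2 to compound 3 (1.00 log units; beyond the scatter), where (oxan-4-yl)methyl takes the place of 1-methylpiperidin-3-yl on a sulfonamide nitrogen. Compounds 1 and 2 alone suggested that this place on the sulfonyl sulfur accepts different amino groups, since a 1.3-fold higher number from compound 1 to compound 2 (0.11 log units; within the scatter), but compound 3 shows that it does not accept all of them, and that exchanging one amino group for another here can cost a large part of the inhibition.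

As compound 3 reads only as a limit, the full size of this loss stays unknown, and the compounds shown cannot say which part of the ((oxan-4-yl)methyl)amino group is responsible. As far as these compounds go, whether a cyclohexylmethylamino group, which has a carbon in place of the ring oxygen, or an (oxan-4-yl)amino group, which lacks the methyl link, would read like compound 1 or like compound 3 remains open.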